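Notes on compound 4: substitution on the aromatic amine

The source may report more compounds than this note shows. Statements on the series, on what has been measured and on what is new or still open speak of the compounds shown alone.

Compound 1 `COc1cc(OC)c(/C=C/S(=O)(=O)Cc2ccc(OC)c(N)c2)c(OC)c1` is the reference point of this small series. In a functional assay on K562 cells (Homo sapiens) for cytotoxicity, read by trypan blue exclusion, with a stated time of 96 h (on this read-out higher numbers stand for weaker inhibition and lower numbers for stronger inhibition), compound 1 gives 2.5 nM, the lowest number of the three measured compounds. Compound 2 `COc1cc(OC)c(/C=C/S(=O)(=O)Cc2cc(N)ccc2OC)c(OC)c1` gives 7500 nM and compound 3 `COc1ccc(CS(=O)(=O)/C=C/c2c(OC)cc(OCCCC(=O)O)cc2OC)cc1N` gives 20000 nM. The step of a 3000-fold higher number from compound 1 to compound 2 (3.48 log units; beyond the scatter) and the step of an 8000-fold higher number from compound 1 to compound 3 (3.90 log units; beyond the scatter) are both large losses, so every change made so far to compound 1 has cost a great deal.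

Compound 4 `COc1ccc(C(Nc2cc(CS(=O)(=O)/C=C/c3c(OC)cc(OC)cc3OC)ccc2OC)C(=O)O)cc1` is not yet measured. It differs from compound 1 as follows: carboxy(4-methoxyphenyl)methyl in place of hydrogen on a nitrogen on an aromatic ring. Neither measured step is the same change. The step from compound 1 to compound 3 is the closer precedent, since it also introduces a carboxy-bearing chain, although on an oxygen rather than on the nitrogen, and it was very large. The step from compound 1 to compound 2 shows that the amine region tolerates little alteration. The amine itself is kept in compound 4, which tempers the comparison. A loss beyond the scatter is therefore expected, though smaller than either measured step.

For compound 4 the estimate in this assay is 100 nM, with a range from 8 nM to 2500 nM. This estimate corresponds to an expected step of a 40-fold higher number from compound 1 to compound 4 (1.60 log units; beyond the scatter).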

Compound 4, half-maximal inhibitory concentration: 15 nM
For compound 4 the middle estimate is 6.7-fold (0.82 log units) above the measured one, and the stated range covers the measured number.
By their numbers in this assay, from the lowest: compound 1; then compound 4; then compound 2; then compound 3.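

In this assay the change on the nitrogen gives a 6.0-fold higher number from compound 1 to compound 4 (0.78 log units; beyond the scatter) and leaves compound 4 at 15 nM, so this aromatic amine nitrogen of compound 1 accepts carboxy(4-methoxyphenyl)methyl, a group of 12 heavy atoms with its own aromatic ring, at a modest cost that still lies beyond the scatter. Among the compounds shown here, the two earlier changes were both large, a 3000-fold higher number from compound 1 to compound 2 (3.48 log units; beyond the scatter) and an 8000-fold higher number from compound 1 to compound 3 (3.90 log units; beyond the scatter), so this is the first change to compound 1 in the series that does not carry a large loss, and a carboxy-bearing substituent is thus not costly to the same degree at both places where it appears, the nitrogen in compound 4 and the oxygen in compound 3. Nothing in hand bears on the reason for this tolerance on the nitrogen.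

The compounds shown do not separate the contributions of the carboxylic acid and the 4-methoxyphenyl ring within the new group. A 4-methoxybenzyl group without the acid, a plain carboxymethyl group or a methyl ester of the acid on the same nitrogen would each address that question.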